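The compounds below may be only part of what the source reports. "The series", "measured", "known", "first", "only" and "open" are said of these compounds alone.

Compound 1 `O=C(NC1CCN(C2CC2)C1)c1cc(-c2ccc(NS(=O)(=O)c3cccc(Cl)c3Cl)cc2)nc2[nH]ncc12` carries a 1-cyclopropylpyrrolidin-3-yl group on an amide-type nitrogen. Going by the values given here, in an assay for inhibition of serine/threonine-protein kinase Sgk1 (Homo sapiens), with stated times of 30 min and 60 min, in the presence of a further agent that is not named here (on this read-out lower numbers stand for stronger inhibition and higher numbers for weaker inhibition), compound 1 gives 6 nM, the only plain number in this small set. Compound 2 `NCCNC(=O)c1cc(-c2ccc(NS(=O)(=O)c3cccc(Cl)c3Cl)cc2)nc2[nH]ncc12` differs in that one place, with 2-aminoethyl on the amide-type nitrogen. In this assay compound 2 gives < 1 nM, which is a limit of the assay and not a number. From the compounds shown here alone, the step of an at least 6.0-fold lower number from compound 1 to compound 2 (0.77 log units; beyond the scatter) is a gain in inhibition whose full size stays open because the limit of < 1 nM in this assay, at which 1 of the 2 values shown sits, caps what can be reported. Compound 3 `CN1CC(NC(=O)c2cc(-c3ccc(NS(=O)(=O)c4cccc(Cl)c4Cl)cc3)nc3[nH]ncc23)C1` alters the same position: 1-methylazetidin-3-yl in place of 1-cyclopropylpyrrolidin-3-yl on an amide-type nitrogen. Among the compounds with values here, only that one measured step bears on this change. The group entering compound 3 is again smaller than the one it replaces, yet it keeps a ring-bound nitrogen rather than the free chain amine of compound 2, so the gain seen in an at least 6.0-fold lower number from compound 1 to compound 2 (0.77 log units; beyond the scatter) is taken only in part. The step is expected to be a 2.0-fold lower number from compound 1 to compound 3 (0.30 log units; within the scatter). In this assay compound 3 is expected to give about 3 nM, with a likely range from 0.8 nM to 12 nM.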

Compound 3, half-maximal inhibitory concentration: < 1 nM
Compound 3 ended at the assay's limit; the forecaster's own chance of this, stated with the estimate: 15%; middle value at least 3.0-fold (0.47 log units) from the limit.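

The step of an at least 6.0-fold lower number from compound 1 to compound 3 (0.77 log units; beyond the scatter) shows that the gain at this position does not depend on the open chain of 2-aminoethyl, since 1-methylazetidin-3-yl, with its nitrogen held in a ring, goes with a gain as well. In this assay compound 3 gives < 1 nM, which is a limit of the assay and not a number. The order of compound 2 and compound 3 cannot be read, and the full size of the gain stays unknown because the reported values stop there: the limit of < 1 nM in this assay, at which 2 of the 3 values shown sit.

Compound 1 and compound 3 differ both in ring size and in the group on the ring nitrogen, so the shown compounds do not tell which of the two changes goes with the gain. A 1-methylpyrrolidin-3-yl or a 1-cyclopropylazetidin-3-yl group on the same amide-type nitrogen would separate these two changes, while a plain alkyl chain with no amine would ask whether a nitrogen in this group matters at all.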